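The source may hold more compounds than are shown below. What is called first, only, known or untested is meant among the compounds shown, and "the series" means these compounds.

For the measured compounds named here, in a physicochemical assay for solubility, with a stated time of 18 h, at pH 7.4 (a lower number here means a less soluble compound, a higher number a more soluble compound), compound 3 `COc1ccc(F)cc1CNCCCNc1ccnc2cc(-c3cccc4ccccc34)ccc12` gives 32000 nM, the highest of the three numbers measured so far; compound 1 `COc1cccc(Oc2ccc3c(NCCCNCc4cc(F)ccc4OC)ccnc3c2)c1` gives 14500 nM, and compound 2 `CCC(CC)c1ccc2c(NCCCNCc3cccc(OC)c3O)ccnc2c1` gives 4200 nM, the number furthest from compound 3. Compound 4 `CCC(CC)c1ccc2c(NCCCNCc3cc(F)ccc3OC)ccnc2c1` has not yet been measured. It differs from compound 3 at a single spot: pentan-3-yl in place of naphthalen-1-yl on an aromatic carbon. One measured step changes the group at this same spot, a 2.2-fold higher number from compound 1 to compound 3 (0.34 log units; beyond the scatter), where one aromatic group replaced another. Going by the values given here, no measured step swaps an aromatic group for pentan-3-yl, so the direction of such a swap is read from compound 2, which already carries pentan-3-yl at this spot, though with a different side chain, and whose number lies well under that of compound 3. A drop is therefore expected for compound 4, and the step of a 4.0-fold lower number from compound 3 to compound 4 (0.60 log units; beyond the scatter) describes that expectation. Compound 4 is estimated at 8000 nM, within a range from 3000 nM to 25000 nM.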

Compound 4, solubility: 4200 nM
Beside the measured number, compound 4's estimate is 1.9-fold (0.28 log units) above it; measured number inside the range.
By their numbers in this assay, from the lowest: compounds 2 and 4 (each within the scatter of the next); then compound 1; then compound 3.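

In this assay, pentan-3-yl in place of naphthalen-1-yl gives a 7.6-fold lower number from compound 3 to compound 4 (0.88 log units; beyond the scatter) with the side chain held the same, and pentan-3-yl in place of 3-methoxyphenoxy gives a 3.5-fold lower number from compound 1 to compound 4 (0.54 log units; beyond the scatter) on that same side chain. So, among these three compounds, both aromatic groups at this position stand above the open-chain pentan-3-yl. With pentan-3-yl fixed, 5-fluoro-2-methoxyphenyl in place of 2-hydroxy-3-methoxyphenyl on the side chain gives no change at the digits printed from compound 2 to compound 4 (within the scatter) and so leaves the number where it was.

Still open, going by these compounds, is how a group such as an amine, a carboxylic acid or a shorter chain like ethyl would fare at this position, and whether the side-chain swap would also leave the number unmoved with naphthalen-1-yl in place. No supporting measurement bears on why the numbers differ.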